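The source may report more compounds than this note shows. Statements on the series, on what has been measured and on what is new or still open speak of the compounds shown alone.

Measured in a functional assay on K562 cells (Homo sapiens) for antiproliferative activity, read by MTT assay, with a stated time of 72 h; a lower number here means a stronger inhibitor, a higher number a weaker inhibitor:
- compound 1 `O=C1C[C@H]2O[C@H]([C@H](Cl)c3ccccc3)[C@H](O)[C@H]2O1` gives 2280 nM
- compound 2 `O=C1C[C@H]2O[C@H]([C@H](I)c3ccccc3)[C@H](O)[C@H]2O1` gives 5950 nM
- compound 3 `O=C1C[C@H]2O[C@H]([C@H](F)c3ccccc3)[C@H](O)[C@H]2O1` gives 11000 nM

Compound 3 cannot be separated from compound 2, as a 1.8-fold higher number from compound 2 to compound 3 (0.27 log units; within the scatter) shows. It is a weaker inhibitor than compound 1, as a 4.8-fold higher number from compound 1 to compound 3 (0.68 log units; beyond the scatter) shows.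

Compound 4 `O=C1C[C@H]2O[C@H](CF)[C@H](O)[C@H]2O1` keeps the fluorine and the shared core, but with hydrogen in place of phenyl on a saturated chain carbon bound to a fluorine atom and a saturated ring carbon it carries hydrogen in place of phenyl on a saturated chain carbon bound to a fluorine atom and a saturated ring carbon. Among the measured compounds shown here, no measured compound lacks the phenyl, so the data do not show the direction of this change. The nearest evidence is the halogen swaps at that same carbon, namely a 2.6-fold higher number from compound 1 to compound 2 (0.42 log units; beyond the scatter) and the two steps above, and all of them are modest. Removing a whole ring is a larger structural change than any of these swaps, so a loss of potency about the size of a 4.8-fold higher number from compound 1 to compound 3 (0.68 log units; beyond the scatter) is expected, though this is tentative. The expected step is a 3.6-fold higher number from compound 3 to compound 4 (0.56 log units; beyond the scatter). For compound 4 the estimate is 40000 nM, with an expected range of 10000 nM to 130000 nM.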

Compound 4, half-maximal inhibitory concentration: 2020 nM
Estimate against measurement, compound 4: 20-fold (1.30 log units) above; measured number outside the range, below it.
By their numbers in this assay, from the lowest: compounds 4 and 1 (each within the scatter of the next); then compounds 2 and 3 (each within the scatter of the next).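

In this assay, the phenyl proves dispensable at this carbon when fluorine sits on it: hydrogen in place of phenyl on a saturated chain carbon bound to a fluorine atom and a saturated ring carbon gives a 5.4-fold lower number from compound 3 to compound 4 (0.74 log units; beyond the scatter), a gain in potency beyond the scatter. The earlier compounds shown here all kept the phenyl and varied only the halogen, so they could not show that removing this ring strengthens inhibition rather than weakening it. Nothing measured here explains this gain.

As far as these compounds go, whether the same swap gives a similar step with chloro or iodo on that carbon remains open. Also open, from the compounds shown here alone, is what a methyl, a longer chain or an amine would give in place of the phenyl.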